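Swapping an Aryl Group on Two Related Cores

This account rests on a few compounds, and the source may have more. Where it says the series, first, only, none or still open, it means among the compounds named here.

Three compounds have been measured so far:

compound 1, `CN(C)c1ccc(/C=C(\C(=O)c2ccc(Cl)cc2)S(=O)(=O)c2ccc(Br)cc2)cc1`, > 100000 nM
compound 2, `COc1ccc(/C=C(\C(=O)c2ccc(Cl)cc2)S(=O)(=O)c2ccc(Br)cc2)cc1O`, 10000 nM
compound 3, `CN(C)c1ccc(/C=C(/SCc2ccc(F)cc2)C(=O)c2ccc(Br)cc2)cc1`, 50000 nM

The read-out is a functional assay on DU-145 cells (Homo sapiens) for inhibition, read by trypan blue exclusion, with a stated time of 96 h; on this read-out higher numbers stand for weaker inhibition of growth and lower numbers for stronger inhibition of growth. In this assay compound 1 gives only a limit, > 100000 nM. Compound 2, which carries the change (3-hydroxy-4-methoxyphenyl in place of 4-(dimethylamino)phenyl on a double-bonded chain carbon bound to a double-bonded chain carbon), gives 10000 nM in this assay. That move is an at least 10-fold lower number from compound 1 to compound 2 (1.00 log units; beyond the scatter), and its true size is known only as a lower bound because of the limit of > 100000 nM in this assay, at which 1 of the 3 values shown sits.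

Compound 3 sits on a different core, and the difference between the cores of compound 1 and compound 3 is not broken down here. In this assay compound 3 gives 50000 nM, the highest of the two numbers that are not limits, and a step beyond the scatter above compound 2.

Compound 4, `COc1ccc(/C=C(/SCc2ccc(F)cc2)C(=O)c2ccc(Br)cc2)cc1O`, is not yet measured. It differs from compound 3 by 3-hydroxy-4-methoxyphenyl in place of 4-(dimethylamino)phenyl on a double-bonded chain carbon bound to a double-bonded chain carbon, the same change, at the same place, that separates compound 1 from compound 2. If that change acts alike on this second core, compound 4 is expected to show a 10-fold lower number from compound 3 to compound 4 (1.00 log units; beyond the scatter) in this assay, a step of roughly the same order as the one from compound 1 to compound 2, though with more uncertainty since only one example of the change is known and that one is a bound rather than a number. On that basis compound 4 is estimated to give about 5000 nM in this assay, most likely between 1500 nM and 20000 nM.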

Compound 4, concentration for 50% growth inhibition: 1000 nM
Compound 4: the middle estimate sits 5.0-fold (0.70 log units) above what was measured; measured number below the stated range.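

On the second core, in this assay, 3-hydroxy-4-methoxyphenyl in place of 4-(dimethylamino)phenyl on a double-bonded chain carbon bound to a double-bonded chain carbon gives a 50-fold lower number from compound 3 to compound 4 (1.70 log units; beyond the scatter), so the number falls with this change on both cores shown, and the direction of the step carries from one core to the other: the same change on two cores in this assay, an at least 10-fold lower number (1.00 log units; beyond the scatter) from compound 1 to compound 2 and a 50-fold lower number (1.70 log units; beyond the scatter) from compound 3 to compound 4; the limit leaves it open whether they differ Compound 1 gives > 100000 nM, which is a limit. The two steps therefore do not show whether the size of the change carries over, since the step on the first core could be smaller than, equal to or larger than the one on the second, and two cores say nothing about how the change would behave on any further core in the series.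

The compounds shown leave open whether the hydroxyl or the methoxy accounts for the step, as the two appear only together, and a phenyl carrying just one of them would separate their contributions. They also leave open how other groups at this place would compare, such as a plain phenyl, a primary amine or a carboxylic acid, and whether any of them would follow the same course on both cores.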